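The source may report more compounds than this note shows. Statements on the series, on what has been measured and on what is new or still open speak of the compounds shown alone.

Working notes on the series. Within the data shown here, compound 2 `O=C(Nc1ccc(Cl)c(-c2nnc3c(Cl)cccn23)c1)c1ccc(F)cc1Cl` is the one member that gives a number rather than a limit in a functional assay on MDA-MB-231 cells (Homo sapiens) for antiproliferative activity, read by MTT assay, with stated times of 72 h and 4 h; a lower number here means a stronger inhibitor, a higher number a weaker inhibitor: compound 2 gives 75000 nM. Compound 1 `O=C(Nc1ccc(Cl)c(-c2nnc3c(Cl)cccn23)c1)c1ccc(C(F)(F)F)cc1Cl` reaches only a limit of the assay in this assay, where compound 1 gives > 100000 nM. Compound 3 `Cc1nc(C(=O)Nc2ccc(Cl)c(-c3nnc4c(Cl)cccn34)c2)cs1` likewise sits at a limit in this assay, where compound 3 gives > 100000 nM. Two of the three values shown thus rest on the same limit (the limit of > 100000 nM in this assay, at which 2 of the 3 values shown sit). The step of an at least 1.3-fold lower number from compound 1 to compound 2 (0.12 log units; that floor lies within the scatter) and the step of an at least 1.3-fold higher number from compound 2 to compound 3 (0.12 log units; that floor lies within the scatter) are therefore floors only, each within the scatter.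

Compound 4 `O=C(Nc1ccc(Cl)c(-c2nnc3c(Cl)cccn23)c1)c1cccnc1` differs from compound 2 at the amide side: pyridin-3-yl in place of 2-chloro-4-fluorophenyl on a carbonyl carbon. The step that bears most directly on it is an at least 1.3-fold higher number from compound 2 to compound 3 (0.12 log units; that floor lies within the scatter), where 2-methyl-1,3-thiazol-4-yl entered on a carbonyl carbon and the number moved to the limit; the step of an at least 1.3-fold lower number from compound 1 to compound 2 (0.12 log units; that floor lies within the scatter) changed only a substituent on an aromatic carbon and bears less. Neither gives a measured size, so no step beyond the scatter can be expected in this assay in either direction, while a return to the limit remains a live possibility.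

Compound 4 is estimated at 100000 nM in this assay, with a range from 30000 nM to 300000 nM. The step of a 1.3-fold higher number from compound 2 to compound 4 (0.12 log units; within the scatter) is thus expected to stay within the scatter.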

Compound 4, half-maximal inhibitory concentration: > 100000 nM
Compound 4 ended at the assay's limit (the forecaster's own chance of this, stated with the estimate: 55%); the middle value sits exactly at the limit.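

At the carbonyl carbon, pyridin-3-yl is a second replacement for 2-chloro-4-fluorophenyl, after 2-methyl-1,3-thiazol-4-yl, that gives no number in this assay, and it does so with fewer heavy atoms and with a hydrogen-bond acceptor that 2-chloro-4-fluorophenyl lacks. As far as these compounds go, the step, an at least 1.3-fold higher number from compound 2 to compound 4 (0.12 log units; that floor lies within the scatter), is only a floor, so its true size remains unknown, and the step between the two replacements cannot be read. The value of compound 4 is a limit of the assay and not a number, and compound 4 now joins compound 1 and compound 3 there: the limit of > 100000 nM in this assay, at which 3 of the 4 values shown sit.

In this assay compound 2 gives 75000 nM, the only number in the set, so the compounds shown do not establish which changes at this carbonyl carbon could give a clearly lower number. From the compounds shown here alone, it remains open whether an amine such as morpholine, a carboxylic acid or a longer alkyl chain in place of the aromatic group would give a readable value, and what a change to the shared core would do.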